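The source may hold more compounds than are shown below. What is called first, only, known or untested is meant among the compounds shown, and "the series" means these compounds.

Measured compounds in an ADME assay on RD cells (Homo sapiens) for cytotoxicity; a higher number here means that more compound is tolerated, a lower number that less compound is tolerated:
Compound 1, `O=C1Nc2ccccc2/C1=N/NC(=S)Nc1ccccc1`, gives > 25000 nM, a limit of the assay.
Compound 2, `CN1C(=O)/C(=N\NC(=S)Nc2ccccc2)c2ccccc21`, gives > 25000 nM, again a limit of the assay.
Compound 3, `O=C1Nc2ccccc2/C1=N/NC(=S)Nc1ccc(Br)cc1`, gives > 25000 nM, again a limit of the assay.

Compound 1 therefore stands at the limit of this assay, with no number of its own; all three values sit there, as the limit of > 25000 nM in this assay, at which 3 of the 3 values shown sit, records. Compound 4, `O=C1Nc2ccc(Br)cc2/C1=N/NC(=S)Nc1ccccc1`, differs from compound 1 by bromo in place of hydrogen on an aromatic carbon of a six-membered aromatic ring of carbon only, part of a fused or bridged system of two rings. Within the data shown here, two measured steps bear on this change: a step that the two limits leave unreadable from compound 1 to compound 2 and a step that the two limits leave unreadable from compound 1 to compound 3. Both are left unreadable by the limits at their two ends, so neither gives a size. Compound 3 carries a bromo on an aromatic carbon elsewhere in the molecule and also sits at the limit. With every value in this assay stopping at the limit, no step beyond the scatter is expected for compound 4; the step from compound 1 to compound 4 is estimated as a step that the limit leaves unreadable from compound 1 to compound 4. Compound 4 is accordingly estimated at 30000 nM, between 15000 nM and 60000 nM, and most likely reported as a limit once more.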

Compound 4, half-maximal cytotoxic concentration: > 25000 nM
Compound 4: a limit, no number; the forecaster's own chance of this, stated with the estimate: 85%; the middle value is on the limit's open side.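

Compound 4 gives > 25000 nM in this assay, a limit and not a number. Among these compounds, with compound 1 also at a limit, no step from compound 1 to compound 4 can be read. The compounds shown leave open whether any change to the core of compound 1 would give a readable cytotoxic concentration, the only value reached so far being: the limit of > 25000 nM in this assay, at which 4 of the 4 values shown sit.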